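The source may hold more compounds than are shown below. What is called first, only, known or untested is meant among the compounds shown, and "the series" means these compounds.

Measured compounds in an assay for inhibition of Thromboxane-A synthase (Homo sapiens), using microsomes; on this read-out higher numbers stand for weaker inhibition and lower numbers for stronger inhibition:
compound 1, `O=C(O)CC/C=C\CC1COC(c2cccs2)OC1c1cccnc1`: 71 nM
compound 2, `CSc1ccc(OC(C)(C)C2OCC(C/C=C\CCC(=O)O)C(c3cccnc3)O2)c([N+](=O)[O-])c1`: 22 nM
compound 3, `COc1ccc(OC(C)(C)C2OCC(C/C=C\CCC(=O)O)C(c3cccnc3)O2)cc1`: 41 nM

Compound 3 holds the second highest of the three numbers in this assay. Its nearest neighbour is compound 1, compound 2 lies a little further off, and both gaps are within the scatter, so the three compounds cannot be ranked on these data.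

Compound 4, `CC(C)(Cc1ccccc1)C1OCC(C/C=C\CCC(=O)O)C(c2cccnc2)O1`, is not yet measured. It differs from compound 3 in one place: benzyl in place of 4-methoxyphenoxy on a saturated chain carbon bound to two saturated chain carbons and a saturated ring carbon. For the measured compounds named here, the one measured step, a 1.9-fold higher number from compound 2 to compound 3 (0.27 log units; within the scatter), exchanges a group on the oxygen on a saturated carbon and stays within the scatter; it bears on the same region but keeps that oxygen, which in compound 4 is gone. Compound 1 carries neither of the exchanged groups and still sits within the scatter of compound 3, so this region has so far tolerated change without a step beyond the scatter. Going by the values given here, no measured step covers the loss of the oxygen itself, and that is the open point.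

On this basis compound 4 is expected to give about 45 nM in this assay, with a range of 15 nM to 150 nM. The expected step of a 1.1-fold higher number from compound 3 to compound 4 (0.04 log units; within the scatter) is therefore within the scatter, with the range widened for the untested change.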

Compound 4, half-maximal inhibitory concentration: 12 nM
Compound 4: the middle estimate sits 3.8-fold (0.57 log units) above what was measured; the whole stated range lies above it.
By their numbers in this assay, from the lowest: compounds 4, 2, 3 and 1 (each within the scatter of the next, the first and the last beyond it).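

In this assay the exchange of 4-methoxyphenoxy for benzyl gives a 3.4-fold lower number from compound 3 to compound 4 (0.53 log units; beyond the scatter) and so is a change beyond the scatter, where the earlier step, which kept the oxygen on a saturated carbon, was not; what sits on the saturated chain carbon bound to two saturated chain carbons and a saturated ring carbon therefore affects the read-out, and a benzyl group without oxygen is well accepted there. The larger exchange of thiophen-2-yl for 1-benzyl-1-methylethyl on a saturated ring carbon gives a 5.9-fold lower number from compound 1 to compound 4 (0.77 log units; beyond the scatter) and also lies beyond the scatter, though it replaces the whole group and cannot be assigned to any one part of it. No independent data on these compounds bear on the origin of either step.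

Still open, from the compounds shown here alone, is whether the lower number follows from the benzyl ring itself or from the loss of the oxygen, which a phenethyl group or an amine link at this place could help separate. Also open, going by these compounds, is how far the benzyl ring accepts substitution, for example a fluorine or a carboxylic acid on that ring.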